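Methoxy Addition on Two Related Cores in U-251 Growth Inhibition

This account rests on a few compounds, and the source may have more. Where it says the series, first, only, none or still open, it means among the compounds named here.

Measured compounds:
Compound 1 `O=C1C=COC(/C=C/c2ccccc2)C1`: 122 uM
Compound 2 `COc1ccc(/C=C/C2CC(=O)C=CO2)cc1`: 152 uM
Compound 3 `COc1ccc(/C=C/C2CC=CC(=O)N2)cc1`: 981 uM

Of the compounds shown here, three have been tested in a functional assay on U-251 cells (Homo sapiens) for inhibition, read by sulforhodamine B assay, with a stated time of 48 h; on this read-out lower numbers stand for stronger inhibition of growth and higher numbers for weaker inhibition of growth. Compound 1 `O=C1C=COC(/C=C/c2ccccc2)C1` gives 122 uM in this assay, and compound 2 `COc1ccc(/C=C/C2CC(=O)C=CO2)cc1` gives 152 uM. The two differ only by methoxy in place of hydrogen on an aromatic carbon, and the step of a 1.2-fold higher number from compound 1 to compound 2 (0.10 log units; within the scatter) is a small one. Compound 3 `COc1ccc(/C=C/C2CC=CC(=O)N2)cc1` carries a different core; how its core differs from that of compound 1 is not broken down here. In this assay compound 3 gives 981 uM, which stands well apart from the numbers of compound 1 and compound 2.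

Compound 4 `COc1ccc(/C=C/C2CC=CC(=O)N2)cc1OC` has not yet been measured. It differs from compound 3 by methoxy in place of hydrogen on an aromatic carbon. Among the measured compounds shown here, this is the same kind of change as the one from compound 1 to compound 2, though not the same: in compound 2 the new group sits para to a group of 9 heavy atoms, whereas in compound 4 it sits ortho to a methoxy group (2 heavy atoms) and meta to a group of 9 heavy atoms. For the measured compounds named here, the only guide is the step of a 1.2-fold higher number from compound 1 to compound 2 (0.10 log units; within the scatter), which stayed within the scatter. On that basis the step from compound 3 to compound 4 is expected to be a 1.0-fold higher number from compound 3 to compound 4 (0.01 log units; within the scatter), small as well. Compound 4 is therefore estimated at 1000 uM in this assay, with a likely range from 400 uM to 2500 uM, because compound 3 already gives 981 uM.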

Compound 4, concentration for growth inhibition (reported as GI): > 964 uM
Compound 4 was reported as a limit; the forecaster's own chance of this, stated with the estimate: 30%; the middle value is on the limit's open side.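

In this assay compound 4 is reported only as a limit, > 964 uM, not as a number, so the step from compound 3 to compound 4 cannot be read. The compounds shown leave open whether methoxy in place of hydrogen on an aromatic carbon changes growth inhibition on the core of compound 3 as little as a 1.2-fold higher number from compound 1 to compound 2 (0.10 log units; within the scatter) on the core of compound 1.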